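Sulfonamide Variation on a Shared Core: Compound 1 to Compound 4

The compounds below may be only part of what the source reports. "The series", "measured", "known", "first", "only" and "open" are said of these compounds alone.

Compound 1, `CCC(C)N(C(C)CC)S(=O)(=O)c1ccc(NC(=O)C(C)(O)C(F)(F)F)cc1`: in an assay on a protein complex (Cavia porcellus) with sulfonylurea receptors; K-ATP channels (Homo sapiens) as the target (a lower number here means a stronger inhibitor, a higher number a weaker inhibitor), compound 1 gives > 30000 nM, which is a limit of the assay and not a number.
Compound 2, `CC(O)(C(=O)Nc1ccc(-c2nn[nH]n2)cc1)C(F)(F)F`: in this assay compound 2 gives > 30000 nM, again a limit.
Compound 3, `CC(O)(C(=O)Nc1ccc([C@@H](O)c2ccccc2)cc1)C(F)(F)F`: in this assay compound 3 gives > 30000 nM, also a limit.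

Compound 1 therefore stands only at a limit, as do the two other measured compounds, so that all three sit together at the limit of > 30000 nM in this assay, at which 3 of the 3 values shown sit. Among the compounds with values here, the one step between measured compounds that differ in one place, a step that the two limits leave unreadable from compound 2 to compound 3, runs between two limits and its size cannot be read.

Compound 4, `CCCN(CCC)S(=O)(=O)c1ccc(NC(=O)C(C)(O)C(F)(F)F)cc1`, differs from compound 1 in one place: dipropylamino in place of bis(sec-butyl)amino on a sulfonyl sulfur. No measured step touches this sulfonyl position, and the only step that is shown at all gives no readable size; nothing among the measured compounds points to a change in this assay beyond the scatter in either direction.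

Compound 4 is therefore expected to sit at the limit as well, with an estimate of 40000 nM and a range from 15000 nM to 120000 nM. The step that this estimate means, a step that the limit leaves unreadable from compound 1 to compound 4, is expected to be no more than scatter.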

Compound 4, half-maximal inhibitory concentration: 6440 nM
Compound 4: the middle estimate sits 6.2-fold (0.79 log units) above what was measured; the measured number lies below the stated range.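

Within the data shown here, the sulfonyl position turns out to respond in this assay: dipropylamino in place of bis(sec-butyl)amino on a sulfonyl sulfur gives an at least 4.6-fold lower number from compound 1 to compound 4 (0.66 log units; beyond the scatter), a step beyond the scatter and toward a stronger inhibitor, which no earlier pair could show. The change is a small one, with the chain count going from 9 heavy atoms to 7, no ring on either side and no hydrogen-bond donors or acceptors in either group, yet it is enough to bring a number into view. Compound 4 is the only compound shown with a value that is a number and not a limit, so the assay can now read this series at all: the limit of > 30000 nM in this assay, at which 3 of the 4 values shown sit.

On these data alone, the full size of the step stays open, as the value of compound 1 is only a limit, and one pair cannot separate the loss of heavy atoms from the change from sec-butyl to propyl chains. Also open, as far as these compounds go, is how the number would move with other amines on the same sulfonyl sulfur, such as diethylamino, dibutylamino or a cyclic amine like piperidine.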